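The compounds below may be only part of what the source reports. "The series", "measured", "known", "first", "only" and "open" are said of these compounds alone.

Measured compounds:
compound 1 `CC(C)N(Cc1cccc(OCCCCCC(=O)O)c1)C(=O)c1ccc(-c2cccc(Oc3ccccc3)c2)cc1` — > 18700 nM
compound 2 `CCOC(=O)CCCCCOc1cccc(CN(C(=O)c2ccc(-c3cccc(OC(C)C)c3)cc2)C(C)C)c1` — > 26000 nM

Both numbers come from an ADME assay on HEK293 cells (Homo sapiens) for cytotoxicity, read by CellTiter-Glo and resazurin assay, with a stated time of 72 h (a higher number here means that more compound is needed for the effect, a lower number that less compound is needed), which measures how much of a compound is needed to harm a human kidney-derived cell line. Neither is a true value. For compound 1 the result > 18700 nM is a limit of the assay, not a number. For compound 2 the result > 26000 nM is likewise a limit. Compound 2 therefore stands at the edge of what the assay can see, as the evidence the limit of > 26000 nM in this assay, at which 1 of the 2 values shown sits, records, and the same holds for compound 1 in the limit of > 18700 nM in this assay, at which 1 of the 2 values shown sits.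

Compound 3 `CCOC(=O)CCCCCOc1cccc(CN(C(=O)c2ccc(-c3cccc(Oc4ccccc4)c3)cc2)C(C)C)c1` is derived from compound 2 by a single change: phenyl in place of isopropyl on an oxygen on an aromatic ring. Compound 3 also shares most of its structure with compound 1, which differs only in the ester versus the acid, and compound 1 gave only a limit. Among the measured compounds shown here, no measured step exists for this change, so the expectation is for no step beyond the scatter; the step that the limit leaves unreadable from compound 2 to compound 3 is expected to be small and most likely a limit is again reported. Compound 3 is expected to give about 30000 nM in this assay, between 15000 nM and 80000 nM.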

Compound 3, half-maximal effective concentration: > 19600 nM
Compound 3 was reported as a limit (the forecaster's own chance of this, stated with the estimate: 85%); the middle value lies beyond the limit too.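

In this assay, compound 1, compound 2 and compound 3 each gave only a limit, and the steps from compound 2 to compound 3 and from compound 1 to compound 3 cannot be read. The compounds shown leave open how much of any of them would actually harm these cells, and whether isopropoxy to phenoxy or acid to ester changes that amount.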